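The source may report more compounds than this note shows. Statements on the series, on what has been measured and on what is new or still open speak of the compounds shown alone.

Measured compounds in an assay on CHO cells for displacement of a labelled ligand from Alpha-2C adrenergic receptor (Homo sapiens); on this read-out higher numbers stand for weaker inhibition and lower numbers for stronger inhibition:
- compound 1 `CC(Oc1ccccc1-c1ccccc1O)C1=NCCN1`: 1620 nM
- compound 2 `Cc1cccc(-c2ccccc2OC(C)C2=NCCN2)c1`: 245 nM

Among the compounds with values here, compound 2 gives the lower of the two numbers in this assay; its only neighbour is compound 1, and the step of a 6.6-fold lower number from compound 1 to compound 2 (0.82 log units; beyond the scatter) lies beyond the scatter. Compound 3 `CC(Oc1ccccc1-c1ccccn1)C1=NCCN1` is not yet measured. It differs from compound 2 in one place: pyridin-2-yl in place of 3-methylphenyl on an aromatic carbon. Within the data shown here, the single measured step, from a 2-hydroxyphenyl to a 3-methylphenyl on the same carbon, showed that the identity of this aryl group moves the number in this assay by a modest amount; no measured pair shows a pyridin-2-yl at this place, so the direction of the present change is not fixed by the data. A step of moderate size toward a higher number is expected, a 2.4-fold higher number from compound 2 to compound 3 (0.39 log units; beyond the scatter), with a wide uncertainty. Compound 3 is estimated at 600 nM, within 200 nM to 2000 nM.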

Compound 3, inhibition constant: 1260 nM
For compound 3 the middle estimate is 2.1-fold (0.32 log units) below the measured one; the range from low to high includes it.
By their numbers in this assay, from the lowest: compound 2; then compounds 3 and 1 (each within the scatter of the next).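

In this assay, the aryl group on this aromatic carbon matters in both directions: replacing 3-methylphenyl with pyridin-2-yl reverses the earlier improvement, with a 5.1-fold higher number from compound 2 to compound 3 (0.71 log units; beyond the scatter) beyond the scatter. Pyridin-2-yl and 2-hydroxyphenyl do not separate, with a 1.3-fold lower number from compound 1 to compound 3 (0.11 log units; within the scatter) within the scatter, so among these three groups only 3-methylphenyl, the one built of carbon alone, stands apart from the other two. Nothing on hand explains why these groups rank as they do.

The compounds shown leave open whether the difference belongs to the methyl group or to the all-carbon ring itself, which an unsubstituted phenyl group would help to separate. Also open, as far as these compounds go, is how the series would respond to a pyridin-3-yl group, or to a phenyl ring carrying an amine or a carboxylic acid.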